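From naphthalen-2-yl to (4-methoxyphenyl)amino on the carbonyl carbon

The source may report more compounds than this note shows. Statements on the series, on what has been measured and on what is new or still open speak of the compounds shown alone.

Values so far in a functional assay on PC-3 cells (Homo sapiens) for inhibition, read by MTT assay, with a stated time of 48 h; a lower number here means a stronger inhibitor, a higher number a weaker inhibitor:
- compound 1 `COc1ccc(C(=O)CSc2nnc(-c3cc(OC)c(OC)c(OC)c3)n2-c2ccc(N(C)C)cc2)cc1` gives 22000 nM
- compound 2 `COc1ccc(C(=O)CSc2nnc(-c3cc(OC)c(OC)c(OC)c3)n2-c2ccc(N(C)C)cc2)cc1O` gives > 100000 nM as a limit of the assay
- compound 3 `COc1cc(-c2nnc(SCC(=O)c3ccc4ccccc4c3)n2-c2ccc(N(C)C)cc2)cc(OC)c1OC` gives 18100 nM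

In this assay compound 3 gives 18100 nM and stands level with compound 1, the measured step being a 1.2-fold lower number from compound 1 to compound 3 (0.08 log units; within the scatter) and so within the scatter. Compound 2 reads only as a limit, > 100000 nM and not a number.

Compound 4 `COc1ccc(NC(=O)CSc2nnc(-c3cc(OC)c(OC)c(OC)c3)n2-c2ccc(N(C)C)cc2)cc1` carries (4-methoxyphenyl)amino in place of naphthalen-2-yl on a carbonyl carbon, counted as (4-methoxyphenyl)amino in place of naphthalen-2-yl on a carbonyl carbon for the change from compound 3. Cut one bond further out, this reads (naphthalen-2-yl)carbonyl to (4-methoxyphenyl)carbamoyl.

Three measured steps act on the group at this carbonyl carbon. Besides the step above, there are an at least 4.5-fold higher number from compound 1 to compound 2 (0.65 log units; beyond the scatter) for hydroxy in place of hydrogen and an at least 5.5-fold lower number from compound 2 to compound 3 (0.74 log units; beyond the scatter) for naphthalen-2-yl in place of 3-hydroxy-4-methoxyphenyl. None of them tests an amino group entering at this place, so the expectation is loose.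

A small step towards a higher number is expected, namely a 2.2-fold higher number from compound 3 to compound 4 (0.34 log units; beyond the scatter) as estimated. For compound 4 the expected value is 40000 nM with an estimated range from 12000 nM to 100000 nM in this series.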

Compound 4, half-maximal inhibitory concentration: 56100 nM
Beside the measured number, compound 4's estimate is 1.4-fold (0.15 log units) below it, and the stated range covers the measured number.
By their numbers in this assay, from the lowest: compounds 3 and 1 (each within the scatter of the next); then compound 4. At a limit, above all of these: compound 2.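

In this assay, keeping the 4-methoxyphenyl group and letting an amino group enter on the carbonyl carbon gives a 2.6-fold higher number from compound 1 to compound 4 (0.41 log units; beyond the scatter), so this place responds to a change in the link to the aromatic ring, a response that the earlier exchange of aromatic groups, a 1.2-fold lower number from compound 1 to compound 3 (0.08 log units; within the scatter), did not show. Set against the naphthalen-2-yl ketone, the same group gives a 3.1-fold higher number from compound 3 to compound 4 (0.49 log units; beyond the scatter), so both measured groups without a hydroxy group read lower than the (4-methoxyphenyl)amino group, though only by modest steps. Compound 2 reads only as a limit and not as a number, so an at least 1.7-fold lower number from compound 2 to compound 4 (0.25 log units; that floor lies within the scatter) sets no order for that pair: the limit of > 100000 nM in this assay, at which 1 of the 4 values shown sits.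

The compounds shown do not tell whether the step belongs to the amide hydrogen or to the nitrogen itself, and a (4-methoxyphenyl)(methyl)amino group on the carbonyl carbon would separate the two. They also leave open whether the step carries over to other aromatic groups, as a (naphthalen-2-yl)amino group at this place would show, or to a saturated amine such as piperidin-1-yl.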